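A few compounds are considered here, and "the series" means these few. Any claim that something is new, unique, unknown or untested is made for them only; others in the source may bear on it.

Compound 2 `COC(=O)c1ccc(OCCCCOc2ccc(C(=O)CC(C)C)c(O)c2C)cc1` enters an assay on HEK293 cells for positive allosteric modulation of metabotropic glutamate receptor 2 (Rattus norvegicus), read by thallium flux, with a stated time of 2.5 min (on this read-out lower numbers stand for an effect already at smaller amounts and higher numbers for an effect only at larger amounts of compound), without a number: for compound 2 the outcome stands as "not determined" (no result reported), and compound 1 `COC(=O)c1ccc(OCCCCOc2ccc(C(=O)CC3CCCC3)c(O)c2C)cc1` likewise stands as "not determined" (no result reported). Going by the values given here, the only numbered reference is compound 3 `Cc1c(OCCCCOc2ccc(C(=O)O)c(Cl)c2)ccc(C(=O)CC2CCCC2)c1O`, which in this assay gives 510 nM. Compound 4 `Cc1c(OCCCCOc2ccccc2C(=O)O)ccc(C(=O)CC(C)C)c1O` differs from compound 2 by 2-carboxyphenyl in place of 4-(methoxycarbonyl)phenyl on an oxygen on a saturated carbon. Among the compounds with values here, no measured pair shows a step of this kind, so the direction of the change cannot be read from the data. Since compound 3, which also carries a carboxyphenyl group, gives 510 nM, compound 4 is expected to land near that value or somewhat weaker, and its estimate in this assay is 1500 nM, with a range from 300 nM to 8000 nM.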

Compound 4, half-maximal effective concentration: 415 nM
Compound 4: the middle estimate sits 3.6-fold (0.56 log units) above what was measured, and the stated range covers the measured number.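

No step can be read between compound 2, which stands without a number, and compound 4. Nothing shown bears on the result. The compounds shown leave open what the change from 4-(methoxycarbonyl)phenyl to 2-carboxyphenyl alone does.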